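Arylidene series: ortho-chloro for meta-fluoro swap

This account rests on a few compounds, and the source may have more. Where it says the series, first, only, none or still open, it means among the compounds named here.

Two members of the shared core have been run in a functional assay on HL-60 cells (Homo sapiens) for cytotoxicity, read by CCK-8 assay, with a stated time of 72 h; on this read-out lower numbers stand for stronger inhibition and higher numbers for weaker inhibition. Compound 1, `C=CCn1c(=O)/c(=C\c2ccc(Cl)c(Cl)c2)[nH]c(=O)/c1=C\c1ccccc1`, gives "not active" (no number reported) in this assay, with no number attached. Going by the values given here, compound 2, `C=CCn1c(=O)/c(=C\c2cccc(F)c2)[nH]c(=O)/c1=C\c1ccccc1OC`, gives 8890 nM in this assay, and that is the only number the series shows so far; nothing else stands beside it for comparison, so its position is simply that of the sole measured point.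

Compound 3, `C=CCn1c(=O)/c(=C\c2ccccc2Cl)[nH]c(=O)/c1=C\c1ccccc1OC`, has not been run. It differs from compound 2 by 2-chlorophenyl in place of 3-fluorophenyl on a double-bonded chain carbon bound to an aromatic carbon. Among the compounds with values here, no step between two measured compounds is available to calibrate this kind of change. The expectation is a small shift toward weaker inhibition, of a size that may not exceed the scatter, expressed as a 1.3-fold higher number from compound 2 to compound 3 (0.13 log units; within the scatter). The estimate for compound 3 in this assay is therefore 12000 nM, with a range from 4000 nM to 40000 nM.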

Compound 3, half-maximal inhibitory concentration: 4200 nM
Compound 3: the middle estimate sits 2.9-fold (0.46 log units) above what was measured, within the range that was stated.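

In this assay, a 2.1-fold lower number from compound 2 to compound 3 (0.33 log units; beyond the scatter) gives the series its first calibrated step at this place, a double-bonded chain carbon bound to an aromatic carbon. The step is modest but beyond the scatter, and it runs toward stronger inhibition, so the aryl group at this place does affect the read-out and 2-chlorophenyl is the better of the two groups compared. Nothing available bears on the origin of this step.

The swap changes the halogen and its location on the ring together, leaving open which of the two matters, or whether both do. Also open, from the compounds shown here alone, is how this place responds to a non-halogen group, such as an amine or a carboxylic acid on the ring.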